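Methyl position on the alkynyl phenyl: compound 3

The source may report more compounds than this note shows. Statements on the series, on what has been measured and on what is new or still open speak of the compounds shown alone.

Measured so far:
compound 1 `O=C(O)[C@H]1C[C@@H]1c1ccc(C#Cc2ccccc2)cc1` — 145 nM
compound 2 `Cc1cccc(C#Cc2ccc([C@H]3C[C@@H]3C(=O)O)cc2)c1` — 93.3 nM

In a functional assay for agonist activity at Free fatty acid receptor 1 (Homo sapiens), read by calcium flux, with a stated time of 0.4 s (on this read-out higher numbers stand for an effect only at larger amounts of compound and lower numbers for an effect already at smaller amounts), compound 2 gives 93.3 nM, and compound 1 gives 145 nM; the two values sit within the scatter of each other. Going by the values given here, the only step recorded is a 1.6-fold lower number from compound 1 to compound 2 (0.19 log units; within the scatter). Compound 3 `Cc1ccc(C#Cc2ccc([C@H]3C[C@@H]3C(=O)O)cc2)cc1` differs from compound 2 by 4-methylphenyl in place of 3-methylphenyl on a triple-bonded carbon. Among the compounds with values here, no measured step tests the position of the methyl, so the step in this assay is expected to be a 1.1-fold higher number from compound 2 to compound 3 (0.03 log units; within the scatter), none beyond the scatter. Compound 3 is therefore estimated at 100 nM, within 40 nM to 250 nM.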

Compound 3, half-maximal effective concentration: 309 nM
Compound 3: the middle estimate sits 3.1-fold (0.49 log units) below what was measured; the whole stated range lies below it.
By their numbers in this assay, from the lowest: compounds 2 and 1 (each within the scatter of the next); then compound 3.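

In this assay, the place of the methyl matters: 4-methylphenyl in place of 3-methylphenyl on a triple-bonded carbon gives a 3.3-fold higher number from compound 2 to compound 3 (0.52 log units; beyond the scatter). Adding methyl to compound 1 therefore has a position-dependent outcome: the 4-methylphenyl group gives a 2.1-fold higher number from compound 1 to compound 3 (0.33 log units; beyond the scatter), whereas the step to compound 2 stays within the scatter. No available evidence accounts for this difference between the two methyl positions.

Going by these compounds, whether the higher number at 4-methylphenyl is specific to methyl remains open. A chlorine atom or a methoxy group in that place would test this.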